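From 3-bromophenyl to 2,3-dimethylphenyl on the sulfonamide nitrogen

The compounds below may be only part of what the source reports. "The series", "measured", "known", "first", "only" and "open" are said of these compounds alone.

Among the measured compounds shown here, in a functional assay on MCF7 cells (Homo sapiens) for antiproliferative activity, read by sulforhodamine B assay, with a stated time of 48 h (on this read-out higher numbers stand for weaker inhibition and lower numbers for stronger inhibition), compound 3 `O=C1NCCN1c1ccc(S(=O)(=O)Nc2cccc(Br)c2)cc1` gives 100 nM, the lowest number so far, against compound 1 `Cc1ccc(NS(=O)(=O)c2ccc(N3CCNC3=O)cc2)cc1C` at 230 nM and compound 2 `O=C1NCCN1c1ccc(S(=O)(=O)Nc2ccccc2)cc1` at 470 nM. Compound 4 `Cc1cccc(NS(=O)(=O)c2ccc(N3CCNC3=O)cc2)c1C` has 2,3-dimethylphenyl in place of 3-bromophenyl on a sulfonamide nitrogen. The closest measured guide is a 2.3-fold lower number from compound 1 to compound 3 (0.36 log units; beyond the scatter), where 3-bromophenyl replaces 3,4-dimethylphenyl. Two further steps frame it: a 2.0-fold higher number from compound 1 to compound 2 (0.31 log units; beyond the scatter) and a 4.7-fold lower number from compound 2 to compound 3 (0.67 log units; beyond the scatter). Going back to a dimethylphenyl group should therefore raise the number modestly in this assay, and the expected step is a 2.4-fold higher number from compound 3 to compound 4 (0.38 log units; beyond the scatter). For compound 4 the estimated value is 240 nM, with an expected range of 100 nM to 550 nM.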

Compound 4, half-maximal inhibitory concentration: 230 nM
Estimate against measurement, compound 4: 1.0-fold (0.02 log units) above; measured number inside the range.
By their numbers in this assay, from the lowest: compound 3; then compounds 1 and 4 (each within the scatter of the next); then compound 2.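

Reading no change at the digits printed from compound 1 to compound 4 (within the scatter) in this assay puts 2,3-dimethylphenyl and 3,4-dimethylphenyl level on the sulfonamide nitrogen, so the two dimethylphenyl patterns shown cannot be told apart in this series. With a 2.0-fold lower number from compound 2 to compound 4 (0.31 log units; beyond the scatter) and a 2.3-fold higher number from compound 3 to compound 4 (0.36 log units; beyond the scatter) the new group keeps an edge over phenyl but not over 3-bromophenyl. Nothing measured here accounts for the lower number with 3-bromophenyl.

Still open, from the compounds shown here alone, is how 3-chlorophenyl, 3-methylphenyl or a phenyl ring carrying an amine or a carboxylic acid would read on this nitrogen.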